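The source may hold more compounds than are shown below. What is called first, only, known or untested is meant among the compounds shown, and "the series" means these compounds.

Working notes on the series in a functional assay on OVCAR-3 cells (Homo sapiens) for antiproliferative activity; on this read-out higher numbers stand for weaker inhibition of growth and lower numbers for stronger inhibition of growth.

Compound 1, `Cc1cccc(-c2cc(O)c3cc(C)cnc3n2)c1`, gives 251 nM in this assay. Compound 2, `Cc1ccc2c(O)cc(-c3cccc(Cl)c3)nc2n1`, carries a chlorine-bearing aryl group in place of the methyl-bearing aryl group of compound 1. In this assay the result of compound 2 is a limit, < 10 nM, and not a number. Compound 2 therefore stands at the potent end of the two values shown, at the limit of < 10 nM in this assay, at which 1 of the 2 values shown sits, so the true gap between compound 1 and compound 2 is not fixed by the data.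

Compound 3, `Cc1cc(C)c2c(O)cc(-c3cccc(Cl)c3)nc2n1`, has not been measured in this assay. It differs from compound 2 by methyl in place of hydrogen on an aromatic carbon. Going by the values given here, no measured pair in the set isolates a change of this kind, so there is no direct precedent for its effect. A single methyl added at a ring carbon is a small change; the expectation is a step from compound 2 to compound 3 of a number no lower from compound 2 to compound 3 (the limit leaves the size open), within the scatter or at most a modest loss.

For compound 3 the estimate in this assay is 10 nM, in the range 3 nM to 40 nM.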

Compound 3, concentration for 50% growth inhibition: 170 nM
Beside the measured number, compound 3's estimate is 17-fold (1.23 log units) below it; measured number above the stated range.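

Going by these compounds alone, this is the first measured step at this position, on the aromatic carbon opposite the ring nitrogen and meta to a methyl group: in this assay, methyl in place of hydrogen gives an at least 17-fold higher number from compound 2 to compound 3 (1.23 log units; beyond the scatter). A single added carbon is therefore not a silent change here, and with the chlorine-bearing aryl group held constant, the position accepts methyl only at a clear cost in growth inhibition. The true size of the step is not fixed and stands as a lower bound because the result of compound 2 is a limit and not a number: the limit of < 10 nM in this assay, at which 1 of the 3 values shown sits.

The compounds shown hold only hydrogen and methyl at this position, so it remains open whether the loss is specific to methyl or extends to other groups there, such as fluorine, a methoxy group, an amine or a longer chain such as ethyl. Also open, as far as these compounds go, is whether the same change carries a comparable cost with the methyl-bearing aryl group of compound 1 in place of the chlorine-bearing aryl group.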